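Methyl in place of fluoro on two related cores

This account rests on a few compounds, and the source may have more. Where it says the series, first, only, none or still open, it means among the compounds named here.

Measured so far in an assay on isolated protein for binding affinity to 5-hydroxytryptamine receptor 1D (Homo sapiens); a lower number here means a stronger inhibitor, a higher number a weaker inhibitor:
- compound 1 `Cc1ccc(-c2n[nH]cc2N2CCCNCC2)cc1`, 892 nM
- compound 2 `Fc1ccc(-c2n[nH]cc2N2CCCNCC2)cc1`, 2190 nM
- compound 3 `Fc1ccc(-c2n[nH]cc2N2CCNCC2)cc1`, reported only as a limit, > 10000 nM

Compounds 1 and 2 share one core and differ in a single place: methyl in place of fluoro on an aromatic carbon. This change gives a 2.5-fold lower number from compound 2 to compound 1 (0.39 log units; beyond the scatter) in this assay. Compound 3 carries a different core; the difference between the two cores is not broken down here. For compound 3 this assay reports no number but a limit, (the limit of > 10000 nM in this assay, at which 1 of the 3 values shown sits).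

Compound 4 `Cc1ccc(-c2n[nH]cc2N2CCNCC2)cc1` is not yet measured. It stands to compound 3 as compound 1 stands to compound 2: methyl in place of fluoro on an aromatic carbon. The two place descriptions are the same word for word, so this is the same kind of change on the second core.

Among the measured compounds shown here, the only guide for the step from compound 3 to compound 4 is the measured one from compound 2 to compound 1, a 2.5-fold lower number from compound 2 to compound 1 (0.39 log units; beyond the scatter), which is modest. On these data alone, because compound 3 gives only > 10000 nM in this assay, its true value is unknown and any number for compound 4 is uncertain. For compound 4 a step of about that modest size is expected, an at least 1.2-fold lower number from compound 3 to compound 4 (0.09 log units; that floor lies within the scatter). Compound 4 is therefore estimated at 8000 nM in this assay, with a range from 3000 nM to 30000 nM, and it may again be reported only as a limit.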

Compound 4, inhibition constant: 325 nM
Compound 4: middle estimate off by 25-fold (1.39 log units), on the high side, and the stated range ends above it.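

In this assay, methyl in place of fluoro on an aromatic carbon gives an at least 30-fold lower number from compound 3 to compound 4 (1.48 log units; beyond the scatter), and the change does not carry from one core to the other at a constant size: the same change on two cores in this assay, a 2.5-fold lower number (0.39 log units; beyond the scatter) from compound 2 to compound 1 and an at least 30-fold lower number (1.48 log units; beyond the scatter) from compound 3 to compound 4, at least 12-fold (1.09 log units) apart, beyond the scatter of two such steps

The direction is the same in both pairs, with the methyl compound giving the lower number on each core, but two pairs show no rule for how large the step will be on any further core, and they do not show what in the cores sets the difference. Compound 3 is reported only as a limit, so the step from it is a floor and its full size remains unknown: the limit of > 10000 nM in this assay, at which 1 of the 4 values shown sits.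

On these data alone, it remains open whether other groups at the same place, such as chloro, methoxy or trifluoromethyl, would also show a core-dependent step in this assay. Also open, as far as these compounds go, is how a methyl or acetyl group on the free amine of either core would shift these values, and whether the methyl and fluoro compounds would keep the same order with that amine substituted.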